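Bromo for Trifluoromethyl on a Weak Dopamine Beta-Hydroxylase Inhibitor

The source may report more compounds than this note shows. Statements on the series, on what has been measured and on what is new or still open speak of the compounds shown alone.

Compound 1 `Oc1ccc(Cn2cc[nH]c2=S)cc1C(F)(F)F`: 120000 nM
Compound 2 `S=c1[nH]ccn1Cc1ccccc1Cl`: 355000 nM

In an assay on isolated protein for inhibition of Dopamine beta-hydroxylase (Rattus norvegicus) (on this read-out higher numbers stand for weaker inhibition and lower numbers for stronger inhibition), compound 1 gives 120000 nM, the lower of the two numbers measured, and compound 2 gives 355000 nM, a gap that lies beyond the scatter. Compound 3 `Oc1ccc(Cn2cc[nH]c2=S)cc1Br` is not yet measured. It differs from compound 1 in one place: bromo in place of trifluoromethyl on an aromatic carbon. Among the compounds with values here, no measured pair shows this change, so a step from compound 1 to compound 3 of at most modest size, in either direction, is expected, and it may well stay within the scatter. Compound 3 is estimated at 100000 nM, within 30000 nM to 400000 nM, an expected step of a 1.2-fold lower number from compound 1 to compound 3 (0.08 log units; within the scatter).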

Compound 3, half-maximal inhibitory concentration: 12000 nM
Beside the measured number, compound 3's estimate is 8.3-fold (0.92 log units) above it; measured number outside the range, below it.
By their numbers in this assay, from the lowest: compound 3; then compound 1; then compound 2.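

In this assay, bromo in place of trifluoromethyl, on an aromatic carbon ortho to a hydroxy group, gives a 10-fold lower number from compound 1 to compound 3 (1.00 log units; beyond the scatter), so this position is sensitive to the group it carries. The change swaps 4 heavy atoms for 1, and neither group has any hydrogen-bond donors or acceptors. No measurement here explains why the step has this size. The compounds shown leave open how a methyl group, an amine or a carboxylic acid at this place would compare with bromo. They also leave open whether the same swap gives a similar step on a core without the hydroxy group.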